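A few compounds are considered here, and "the series" means these few. Any claim that something is new, unique, unknown or untested is made for them only; others in the source may bear on it.

Measured so far:
compound 1, `Cc1ccc(-n2nc(-c3ccccc3)nc2CNc2ccc(C(=O)NO)cc2)cc1`, 310 nM
compound 2, `O=C(NO)c1ccc(NCc2nc(-c3ccc(F)cc3)nn2-c2ccccc2)cc1`, 115 nM

Both compounds were tested in an assay on Sf9 cells for inhibition of protein deacetylase HDAC6 (Homo sapiens), read by fluorescence, with a stated time of 40 min; a higher number here means a weaker inhibitor, a lower number a stronger inhibitor. Compound 2 stands at the lower, stronger end of the two numbers shown; the gap to compound 1, whose value is 310 nM, is beyond the usual scatter, so compound 2 is the stronger of the pair. Going by the values given here, no single-point step between measured compounds is known, so the influence of any one change must be estimated rather than read off.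

Compound 3, `O=C(NO)c1ccc(NCc2nc(-c3ccc(Cl)cc3)nn2-c2ccccc2)cc1`, has not yet been measured. It differs from compound 2 by chloro in place of fluoro on an aromatic carbon. A swap of one halogen for another in the same place is a small change, and it is expected to give a step of a 1.2-fold lower number from compound 2 to compound 3 (0.06 log units; within the scatter), that is, no shift beyond the scatter, perhaps a slight gain. Compound 3 is therefore estimated at 100 nM, within a range from 45 nM to 220 nM.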

Compound 3, half-maximal inhibitory concentration: 181 nM
Estimate against measurement, compound 3: 1.8-fold (0.26 log units) below; measured number inside the range.
By their numbers in this assay, from the lowest: compounds 2, 3 and 1 (each within the scatter of the next, the first and the last beyond it).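

In this assay, changing 4-fluorophenyl to 4-chlorophenyl gives a 1.6-fold higher number from compound 2 to compound 3 (0.20 log units; within the scatter) and so the two halogens cannot be told apart at this place, on an aromatic carbon para to a large group. Going by these compounds alone, this is the first change in a single place that can be read here, since compound 1 and compound 2 differ in more than one place and gave no such comparison. No measurement is available that explains this small step.

As far as these compounds go, the comparison covers only fluoro and chloro, so it remains open whether this place would accept groups of a different kind, such as methoxy, nitrile or an amine. Also open, from the compounds shown here alone, is how compound 2 or compound 3 would compare with a version carrying only hydrogen at this place.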